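Heptyl Chain Exchanged for Fluorobenzyl on the Ring Nitrogen

This account rests on a few compounds, and the source may have more. Where it says the series, first, only, none or still open, it means among the compounds named here.

Compound 1, `CCCn1ccc2cc(/C(C)=C/C(=O)Nc3ccccc3OCCCC(=O)O)ccc21`: 190 nM
Compound 2, `CCCCCCCn1ccc2cc(/C(C)=C/C(=O)Nc3ccccc3OCCCC(=O)O)ccc21`: 120 nM

Of the compounds shown here, two have been measured in an assay on Prostate gland for inhibition of steroid 5-alpha-reductase (Rattus norvegicus); a lower number here means a stronger inhibitor, a higher number a weaker inhibitor. Among the compounds with values here, compound 2 holds the lower of the two numbers, but its only neighbour is compound 1, and the step of a 1.6-fold lower number from compound 1 to compound 2 (0.20 log units; within the scatter) is within the scatter, so the two cannot be ranked against each other.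

Compound 3, `C/C(=C\C(=O)Nc1ccccc1OCCCC(=O)O)c1ccc2c(ccn2Cc2ccc(F)cc2)c1`, is reached from compound 2 by a single change: 4-fluorophenyl in place of hexyl on a saturated chain carbon bound to an aromatic nitrogen. Within the data shown here, the one measured step that touches this position is the lengthening of the chain from compound 1 to compound 2, a 1.6-fold lower number from compound 1 to compound 2 (0.20 log units; within the scatter), which stayed within the scatter. Among the measured compounds shown here, no measured compound carries a ring on this chain carbon, so the effect of an aromatic group here is unknown from the data.

For compound 3 the step of a 1.1-fold lower number from compound 2 to compound 3 (0.04 log units; within the scatter) is therefore expected to stay within the scatter, in either direction. Compound 3 is estimated at 110 nM, with a range from 40 nM to 320 nM.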

Compound 3, half-maximal inhibitory concentration: 97 nM
Estimate against measurement, compound 3: 1.1-fold (0.05 log units) above, within the range that was stated.
By their numbers in this assay, from the lowest: compounds 3, 2 and 1 (each within the scatter of the next).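

The result shows that this position, the saturated chain carbon bound to an aromatic nitrogen, tolerates a ring as well as an open chain in this assay: exchanging hexyl for 4-fluorophenyl gives a 1.2-fold lower number from compound 2 to compound 3 (0.09 log units; within the scatter). The same holds against the shorter chain, with 4-fluorophenyl in place of ethyl giving a 2.0-fold lower number from compound 1 to compound 3 (0.29 log units; within the scatter), so neither change separates the compounds, and the three remain unranked despite the difference between an open chain and one six-membered aromatic ring of carbon only. Nothing is available here that would account for this outcome.

The compounds shown leave open what a plain benzyl group would give on the aromatic nitrogen, and with it whether the fluorine in compound 3 plays any part in the reading, as a single ring carrying a single substituent cannot settle that. They also leave open how far this tolerance reaches, for instance to a 4-methoxybenzyl group, a chain ending in an amine or a chain ending in a carboxylic acid, any of which could show whether this position can produce a step beyond the scatter.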